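Methyl in Place of Ethynyl: What to Expect for Compound 4

The source may hold more compounds than are shown below. What is called first, only, known or untested is meant among the compounds shown, and "the series" means these compounds.

Compound 1 `C#Cc1cc(C(=O)NCCCCc2ccccc2)cc(C2SCC(=O)N2c2ccccc2OC)c1` gives 40.8 nM in a functional assay on HOS-TE85 cells (Homo sapiens) for inhibition, read by CCK-8 assay, with a stated time of 72 h; on this read-out lower numbers stand for stronger inhibition and higher numbers for weaker inhibition. Compound 2 `Cc1cccc(N2C(=O)CSC2c2cccc(C(=O)NCCCCc3ccccc3)c2)c1` gives 93.2 nM in this assay. Compound 3 `C#Cc1cccc(N2C(=O)CSC2c2cccc(C(=O)NCCCCc3ccccc3)c2)c1` gives 149 nM in this assay.

Compound 1 shows the lowest number of the three, and its gaps to compound 2 and compound 3 are beyond the scatter. Between compound 3 and compound 2 the change is methyl in place of ethynyl on an aromatic carbon, and the step it made is a 1.6-fold lower number from compound 3 to compound 2 (0.20 log units; within the scatter), within the scatter.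

Compound 4 `COc1ccccc1N1C(=O)CSC1c1cc(C)cc(C(=O)NCCCCc2ccccc2)c1` is not yet measured. It differs from compound 1 by methyl in place of ethynyl on an aromatic carbon, the same kind of change, though not the same: here the aromatic carbon is meta to two large groups, whereas in compound 3 it is meta to a large group. The difference between the core of compound 1 and the core of compound 3 is not broken down here.

Since the measured step is within the scatter, compound 4 is expected to stand close to compound 1, with a step of about a 1.4-fold lower number from compound 1 to compound 4 (0.13 log units; within the scatter). The estimate for compound 4 is 30 nM, between 12 nM and 75 nM.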

Compound 4, half-maximal inhibitory concentration: 16.2 nM
Estimate against measurement, compound 4: 1.9-fold (0.27 log units) above, within the range that was stated.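

In this assay, methyl in place of ethynyl on an aromatic carbon of the core of compound 1 gives a 2.5-fold lower number from compound 1 to compound 4 (0.40 log units; beyond the scatter). Set beside the same change on the other core, this step cannot be told apart from the earlier one: the same change on two cores in this assay, a 1.6-fold lower number (0.20 log units; within the scatter) from compound 3 to compound 2 and a 2.5-fold lower number (0.40 log units; beyond the scatter) from compound 1 to compound 4, 1.6-fold (0.20 log units) apart, within the scatter of two such steps The change can therefore be carried between these two cores without a measurable difference in its size, but this does not show that the size is fixed, since only the new step lies beyond the scatter, only two cores are compared, and the new methyl is meta to two large groups; nor does it say why the number moves.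

The compounds shown leave open what a chlorine, a nitrile, an amine or a carboxylic acid would do on the same aromatic carbon of the core of compound 1. They also leave open how the step would behave on a core with a shorter chain in the amide, and which of the features that separate the two cores matters.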